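The source may report more compounds than this note shows. Statements on the series, on what has been measured and on what is new or still open speak of the compounds shown alone.

Compound 1 `C[C@@H]1CN(c2sc(CN(C)C)nc2-c2nc3ccccc3[nH]2)CCN1C(=O)Cn1cnc2cccnc21` gives 2360 nM in a functional assay on U2OS cells for antagonist activity at C-X-C chemokine receptor type 3 (Homo sapiens), read by beta-arrestin recruitment; a lower number here means a stronger inhibitor, a higher number a weaker inhibitor.
Compound 2 `CCOc1ncc(-c2nc(C(F)(F)F)sc2N2CCN(C(=O)Cn3ccc4cnccc43)[C@H](C)C2)cn1` gives 23 nM in this assay.

Among the measured compounds shown here, of the two measured compounds, compound 2 stands lowest in this assay; compound 1, its only neighbour, sits far higher, well beyond the scatter. Compound 3 `CCOc1ncc(-c2nc(C(F)(F)F)sc2N2CCN(C(=O)Cn3ccc(C(F)(F)F)n3)[C@H](C)C2)cn1` differs from compound 2 by a group of 9 heavy atoms (4 carbon, 2 nitrogen, 3 fluorine; one five-membered aromatic ring with 2 hetero atoms) in place of a group of 9 heavy atoms (7 carbon, 2 nitrogen; one five-membered aromatic ring with 1 hetero atom, one six-membered aromatic ring with 1 hetero atom), on a saturated chain carbon bound to a carbonyl carbon. For the measured compounds named here, no measured pair shows this exchange, so its effect is open. The expected step is a 2.6-fold higher number from compound 2 to compound 3 (0.42 log units; beyond the scatter), a moderate shift toward a weaker inhibitor, with wide uncertainty. Compound 3 is therefore estimated at 60 nM, with a range from 15 nM to 300 nM.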

Compound 3, half-maximal inhibitory concentration: 93 nM
The estimate for compound 3 lay 1.6-fold (0.19 log units) below the measured number; the range from low to high includes it.
By their numbers in this assay, from the lowest: compound 2; then compound 3; then compound 1.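

Among the compounds shown here, this is the first exchange read at the saturated chain carbon bound to a carbonyl carbon: in this assay, putting 3-(trifluoromethyl)-1H-pyrazol-1-yl in place of the two-ring group gives a 4.0-fold higher number from compound 2 to compound 3 (0.61 log units; beyond the scatter). The step is modest, so at this position a single five-membered ring still gives an inhibitor, though a weaker one. Nothing at hand explains the step.

From the compounds shown here alone, it remains open whether the trifluoromethyl group or the pyrazole ring accounts for the change. Also open, going by these compounds, is how a methyl group or a carboxylic acid on that pyrazole would read here.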